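The source may report more compounds than this note shows. Statements on the series, on what has been measured and on what is new or still open speak of the compounds shown alone.

Compound 1 `CN1CCC[C@H]1[C@@H]1COc2cc(N)ccc2O1`: 3500 nM
Compound 2 `CN1CCC[C@H]1[C@H]1COc2cc(N)ccc2O1`: 8600 nM
Compound 3 `CN1CCC[C@H]1[C@H]1COc2ccc([N+](=O)[O-])cc2O1`: 2100 nM

All three were measured in an assay on membranes from HEK293 cells for displacement of a labelled ligand from Neuronal acetylcholine receptor; alpha3/beta4 (Homo sapiens), with a stated time of 5 min; a higher number here means a weaker inhibitor, a lower number a stronger inhibitor. Compound 1 stands second highest of the three numbers; compound 3 gives a number within the usual scatter of it, while compound 2 lies beyond that scatter. Among the compounds with values here, the only single-place step, a 2.5-fold higher number from compound 1 to compound 2 (0.39 log units; beyond the scatter), rests on the fact that compounds 1 and 2 differ only in the configuration as drawn alone.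

Compound 4 `CN1CCC[C@H]1[C@@H]1COc2cc(O)ccc2O1` changes compound 1 by hydroxy in place of amino on an aromatic carbon. Within the data shown here, no measured step touches this group, and the step between compound 1 and compound 2 concerns configuration only, so it offers no guide to the change. Compound 4 is therefore expected to show no step beyond the scatter in this assay, namely no change at the digits printed from compound 1 to compound 4 (within the scatter). Compound 4 is estimated at 3500 nM, within 1200 nM to 10000 nM.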

Compound 4, inhibition constant: 1900 nM
Estimate against measurement, compound 4: 1.8-fold (0.27 log units) above; measured number inside the range.
By their numbers in this assay, from the lowest: compounds 4, 3 and 1 (each within the scatter of the next); then compound 2.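

The first change measured at this aromatic carbon, hydroxy in place of amino, gives a 1.8-fold lower number from compound 1 to compound 4 (0.27 log units; within the scatter) in this assay. At this position and in this configuration, then, the exchange of amino for hydroxy produces no step beyond the scatter. Nothing available here bears on a cause for this result.

On these data alone, whether the same exchange behaves alike in the configuration of compound 2 remains open. So does the outcome of placing a methoxy group, an amide or a carboxylic acid on this aromatic carbon.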